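This account rests on a few compounds, and the source may have more. Where it says the series, first, only, none or still open, it means among the compounds named here.

Measured compounds:
- compound 1, `COc1ncnc2c1c(-c1ccsc1)cn2[C@@H]1O[C@H](CO)[C@@H](O)[C@H]1O`: 130 nM
- compound 2, `COc1nc(N)nc2c1c(-c1ccsc1)cn2[C@@H]1O[C@H](CO)[C@@H](O)[C@H]1O`: > 20000 nM
- compound 3, `Cc1ncnc2c1c(-c1ccsc1)cn2[C@@H]1O[C@H](CO)[C@@H](O)[C@H]1O`: 350 nM

In a functional assay on HL-60 cells (Homo sapiens) for antiproliferative activity, read by XTT assay, with a stated time of 72 h (on this read-out higher numbers stand for weaker inhibition and lower numbers for stronger inhibition), compound 1 gives 130 nM, the lowest of the two numbers obtained; its nearest neighbour, compound 3, gives 350 nM. For compound 2 the assay reports only a limit, > 20000 nM; this is the limit of > 20000 nM in this assay, at which 1 of the 3 values shown sits, and not a number. The two measured steps from compound 1 are an at least 150-fold higher number from compound 1 to compound 2 (2.18 log units; beyond the scatter) and a 2.7-fold higher number from compound 1 to compound 3 (0.43 log units; beyond the scatter), both at the six-membered part of the shared core.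

Compound 4, `COc1ncnc2c1c(I)cn2[C@@H]1O[C@H](CO)[C@@H](O)[C@H]1O`, differs from compound 1 at the five-membered ring: iodo in place of thiophen-3-yl on an aromatic carbon. Neither measured step touches this position, so neither bears directly on the change. What remains is that a small group replaces a ring of five heavy atoms, and a loss is expected, a 3.5-fold higher number from compound 1 to compound 4 (0.54 log units; beyond the scatter), though the number could also stay within the scatter.

Compound 4 is therefore estimated at 450 nM, within 120 nM to 2500 nM.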

Compound 4, half-maximal inhibitory concentration: 2300 nM
Compound 4: the middle estimate sits 5.1-fold (0.71 log units) below what was measured; the range from low to high includes it.
By their numbers in this assay, from the lowest: compound 1; then compound 3; then compound 4. At a limit, above all of these: compound 2.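

Replacing the group on this carbon of the five-membered aromatic ring has a large effect in this assay (an 18-fold higher number from compound 1 to compound 4 (1.25 log units; beyond the scatter)), the first change at this place among the compounds shown. The steps at the six-membered part do not predict this: the exchange of methoxy for methyl there is modest (a 2.7-fold higher number from compound 1 to compound 3 (0.43 log units; beyond the scatter)), so the thiophen-3-yl group of compound 1 cannot be exchanged for iodo without a clear loss in this assay. Nothing measured here accounts for that loss, whether it follows from the ring, its sulfur or the drop in heavy atoms.

The compounds shown leave open whether another ring on this carbon, such as phenyl or furan-2-yl, would hold the number of compound 1. They also leave open how a single small group other than iodo, such as an amine or a methyl, or a longer chain, would fare at this place.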